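From 2,2,2-Trifluoroethyl to Isopropyl on the Shared Core

The source may hold more compounds than are shown below. What is called first, only, known or untested is meant among the compounds shown, and "the series" means these compounds.

In a functional assay (Left cardiac atrium, Cavia porcellus), with a stated time of 30 min (on this read-out higher numbers stand for an effect only at larger amounts of compound and lower numbers for an effect already at smaller amounts), compound 3 `COc1cccc(C2(OCC(F)(F)F)SC=C(C)n3c2noc3=O)c1` gives 320 nM. Compound 2 `COc1cccc(C2(O)SC=C(C)n3c2noc3=O)c1` gives 490 nM, so the two cannot be told apart: the data show a 1.5-fold lower number from compound 2 to compound 3 (0.19 log units; within the scatter). Compound 1 `CC1=CSC(OC(C)C)(c2ccccc2)c2noc(=O)n21` gives 1190 nM, a higher number than compound 3 and beyond the scatter.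

Compound 4 `COc1cccc(C2(OC(C)C)SC=C(C)n3c2noc3=O)c1` comes from compound 3 by a single change: isopropyl in place of 2,2,2-trifluoroethyl on an oxygen on a saturated carbon. Isopropyl stands in place of 2,2,2-trifluoroethyl on an oxygen on a saturated carbon. Among the compounds with values here, compound 1 also carries isopropyl there, but no measured step isolates that group.

Within the data shown here, the one measured step at this place is a 1.5-fold lower number from compound 2 to compound 3 (0.19 log units; within the scatter). As it stays within the scatter, no step beyond the scatter is expected in this assay. The value of compound 1, 1190 nM, nevertheless argues for leaving room towards higher numbers. The estimated step is a 1.3-fold higher number from compound 3 to compound 4 (0.12 log units; within the scatter). Compound 4 is expected at 420 nM, with an estimated range from 170 nM to 1000 nM.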

Compound 4, half-maximal effective concentration: 64 nM
Compound 4: middle estimate off by 6.6-fold (0.82 log units), on the high side; measured number below the stated range.
By their numbers in this assay, from the lowest: compound 4; then compounds 3 and 2 (each within the scatter of the next); then compound 1.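

Within the data shown here, at the oxygen on a saturated carbon, the earlier compounds showed only a step within the scatter, but in this assay isopropyl in place of 2,2,2-trifluoroethyl gives a 5.0-fold lower number from compound 3 to compound 4 (0.70 log units; beyond the scatter) and so shows that the group at this place can move the read-out. Isopropyl in place of hydrogen gives a 7.7-fold lower number from compound 2 to compound 4 (0.88 log units; beyond the scatter) even though hydrogen and 2,2,2-trifluoroethyl lie within the scatter of each other, so the outcome depends on which group is present, not merely on whether the hydrogen is replaced. With isopropyl held constant, methoxy in place of hydrogen on an aromatic carbon gives a 19-fold lower number from compound 1 to compound 4 (1.27 log units; beyond the scatter) and marks this second place as one that also matters.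

As far as these compounds go, it remains open whether an ethyl group, a tert-butyl group or a longer chain on the same oxygen would match isopropyl. The data offered here give no measured explanation for the gap between isopropyl and 2,2,2-trifluoroethyl.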